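Swapping the amide substituent of a lipopeptide-like agonist

This account rests on a few compounds, and the source may have more. Where it says the series, first, only, none or still open, it means among the compounds named here.

Three compounds share the same core, a lipid-bearing cysteine linked through an amide to a small substituent, and differ only in that substituent. Compound 1 `CCCCCCCCCCCC(=O)OC[C@H](CSC[C@@H](N)C(=O)N[C@H](C)CO)OC(=O)CCCCCCCCCCC` gives 22200 nM in an assay on HEK293 cells for agonist activity at Toll-like receptor 2 (Homo sapiens); on this read-out lower numbers stand for an effect already at smaller amounts and higher numbers for an effect only at larger amounts of compound. Compound 2 `CCCCCCCCCCCC(=O)OC[C@H](CSC[C@@H](N)C(=O)NC(C)c1ccccc1)OC(=O)CCCCCCCCCCC` gives 9900 nM. Compound 3 `CCCCCCCCCCCC(=O)OC[C@H](CSC[C@@H](N)C(=O)NC(CC)COC)OC(=O)CCCCCCCCCCC` gives 71.8 nM, the lowest of the three numbers, with a step of a 310-fold lower number from compound 1 to compound 3 (2.49 log units; beyond the scatter) and of a 140-fold lower number from compound 2 to compound 3 (2.14 log units; beyond the scatter). The smaller step of a 2.2-fold lower number from compound 1 to compound 2 (0.35 log units; beyond the scatter) shows that a phenyl-bearing substituent helped only modestly.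

Compound 4 `CCCCCCCCCCCC(=O)OC[C@H](CSC[C@@H](N)C(=O)NC(C)CCN(CC)CC)OC(=O)CCCCCCCCCCC` differs from compound 3 by 3-(diethylamino)-1-methylpropyl in place of 1-(methoxymethyl)propyl on an amide-type nitrogen. Both large measured steps concern the arrival of the 1-(methoxymethyl)propyl group, which now departs; nothing measured covers a basic amine on this position. Since the departing group carried almost all of the gain of compound 3, the expected step is a 21-fold higher number from compound 3 to compound 4 (1.32 log units; beyond the scatter), a rise in this assay, with wide uncertainty. Compound 4 is therefore expected to give about 1500 nM, within 150 nM to 15000 nM.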

Compound 4, half-maximal effective concentration: 257 nM
Compound 4: middle estimate off by 5.8-fold (0.77 log units), on the high side; the measured number falls inside the stated range.
By their numbers in this assay, from the lowest: compound 3; then compound 4; then compound 2; then compound 1.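

In this assay the step of a 3.6-fold higher number from compound 3 to compound 4 (0.55 log units; beyond the scatter) is modest, so the low number of compound 3 does not depend on 1-(methoxymethyl)propyl alone: 3-(diethylamino)-1-methylpropyl, which carries a nitrogen instead of an oxygen, keeps most of the gain on this amide-type nitrogen. The steps of a 39-fold lower number from compound 2 to compound 4 (1.59 log units; beyond the scatter) and of an 86-fold lower number from compound 1 to compound 4 (1.94 log units; beyond the scatter) are both large and place this new group much closer to compound 3 than to the two weaker compounds. Nothing measured on these compounds accounts for these differences.

On these data alone, it remains open whether the diethylamino end matters or the chain holding it is enough, which a dimethylamino group or a plain hexyl chain on this nitrogen could help separate. A carboxylic acid at the end of the chain is also untested among the compounds shown here.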